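This account rests on a few compounds, and the source may have more. Where it says the series, first, only, none or still open, it means among the compounds named here.

Measured in a functional assay on KB cells (Homo sapiens) for inhibition, read by MTT assay, with a stated time of 24 h, tested at 10 ug/mL; a higher number here means more inhibition of growth at the concentration tested, a lower number less inhibition of growth:
- compound 1 `O=C(CCCCC1CCSS1)Nc1ccccc1Cl`: "not active" (no number reported)
- compound 2 `O=C(CCCCC(S)CCS)Nc1ccccc1`: 8.62%

Going by the values given here, compound 2, at 8.62%, holds the only number in this assay, while compound 1 is reported as "not active" (no number reported) with no number. Compound 3 `O=C(CCCCC(S)CCS)Nc1ccccc1Cl` differs from compound 2 by chloro in place of hydrogen on an aromatic carbon, with chloro in place of hydrogen on an aromatic carbon. Among the compounds with values here, no measured pair shows what this change does. The estimated a number 1.4 percentage points higher from compound 2 to compound 3 (within the scatter) is therefore expected to stay within the usual scatter, with no firm direction. For compound 3 the expected value is 10%, with an estimated range of 0% to 25%.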

Compound 3, percent growth inhibition at one concentration: "not active" (no number reported)
No number was reported for compound 3; the estimate stays without a comparison.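

In this assay, going by these compounds alone, compound 3 gives "not active" (no number reported) and, like compound 1, carries no number, so no step from compound 2 can be read. As far as these compounds go, whether chloro in place of hydrogen changes growth inhibition stays open. No evidence bears on this result.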